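The compounds below may be only part of what the source reports. "The series", "measured", "known", "first", "only" and "open" are said of these compounds alone.

Compound 1 `COc1cc(CNC(=O)CCCCCCC(C)C)ccc1OC(=O)CCC(=O)Oc1ccc(-c2cc(=S)ss2)cc1` gives 5530 nM in a functional assay on HeLa cells (Homo sapiens) for antiproliferative activity, read by MTT assay, with a stated time of 48 h; on this read-out lower numbers stand for stronger inhibition and higher numbers for weaker inhibition. Compound 3 `COc1cc(CNC(=O)CCCC/C=C/C(C)C)ccc1OC(=O)CCC(=O)Oc1ccc(-c2cc(=S)ss2)cc1` gives 4250 nM, and the measured step of a 1.3-fold lower number from compound 1 to compound 3 (0.11 log units; within the scatter) lies within the scatter, so these two values stand level. Compound 2 `COc1cc(CNC(=O)CCCCCCC(C)C)ccc1OC(=O)c1ccc(C(N)=S)cc1` gives only a limit of the assay, > 50000 nM.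

Compound 4 `COc1cc(CNC(=O)CCCCCCC(C)C)ccc1OC(=O)CCC(=O)Oc1ccc(C(N)=S)cc1` keeps the rest of compound 1 and makes one change: a group of 3 heavy atoms (1 carbon, 1 nitrogen, 1 sulfur; no ring) in place of a group of 6 heavy atoms (3 carbon, 3 sulfur; one five-membered aromatic ring with 2 hetero atoms), on an aromatic carbon. Going by the values given here, no measured step makes this exact swap. The step between compound 1 and compound 3 concerns the chain, a different part of the molecule, so it gives little guidance here. Compound 2 carries the entering group too, joined differently to the core, and its > 50000 nM is a limit, so a move to a higher number, meaning weaker inhibition, is expected in this assay. The expected size of the change is a 3.6-fold higher number from compound 1 to compound 4 (0.56 log units; beyond the scatter). For compound 4 the estimated value is 20000 nM, with an expected range from 7000 nM to 50000 nM.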

Compound 4, half-maximal inhibitory concentration: > 50000 nM
Compound 4: a limit, no number; the forecaster's own chance of this, stated with the estimate: 30%; middle value at least 2.5-fold (0.39 log units) from the limit.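

Replacing the five-membered aromatic ring with 2 hetero atoms by the ring-free group of 3 heavy atoms gives an at least 9.0-fold higher number from compound 1 to compound 4 (0.95 log units; beyond the scatter) in this assay. Unlike the chain change between compound 1 and compound 3, this change at the aromatic carbon para to a large group moves the number beyond the scatter, so inhibition in these cells depends on which group sits there. The reading for compound 4 is a limit, not a number, and compound 2 shares it: the limit of > 50000 nM in this assay, at which 2 of the 4 values shown sit.

Compound 2 and compound 4 differ in how the group of 3 heavy atoms is joined to the core, but a comparison between two limits cannot be read. On these data alone, it also remains open how an amine or a carboxylic acid at this same aromatic carbon would compare with the ring of compound 1.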